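The source may report more compounds than this note shows. Statements on the series, on what has been measured and on what is new or still open speak of the compounds shown alone.

Measured compounds:
compound 1 `Cc1nc(-c2ccccc2NCC2=NCCN2)co1` — 324 nM
compound 2 `c1ccc(-c2cnoc2)c(NCC2=NCCN2)c1` — 45.7 nM

In a functional assay for activation of Alpha-1A adrenergic receptor (Homo sapiens), read by calcium flux (a lower number here means that less compound is needed, a higher number that more compound is needed for the effect), compound 2 gives 45.7 nM, the lowest of the two numbers at hand. For the measured compounds named here, its nearest neighbour is compound 1, which gives 324 nM in this assay; the one measured step, a 7.1-fold lower number from compound 1 to compound 2 (0.85 log units; beyond the scatter), is modest but beyond the scatter.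

Compound 3 `Cc1ccc(-c2ccccc2NCC2=NCCN2)o1` has not yet been measured. It differs from compound 2 in one place: 5-methylfuran-2-yl in place of 1,2-oxazol-4-yl on an aromatic carbon. Going by the values given here, only the step from compound 1 to compound 2 bears on this change, and only loosely, since it exchanged one five-membered aromatic ring for another and removed a methyl group, whereas here a methyl group returns on a ring with one hetero atom. On that thin basis a moderate rise in the number is expected for compound 3, roughly a 2.6-fold higher number from compound 2 to compound 3 (0.42 log units; beyond the scatter), with compound 3 estimated at 120 nM in this assay, in the range 40 nM to 400 nM.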

Compound 3, half-maximal effective concentration: 2.69 nM
Estimate against measurement, compound 3: 45-fold (1.65 log units) above; measured number outside the range, below it.
By their numbers in this assay, from the lowest: compound 3; then compound 2; then compound 1.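

For the compounds shown here, at this place, on an aromatic carbon of a six-membered aromatic ring of carbon only, the identity of the five-membered ring can matter far more than the one earlier step showed: in this assay, 5-methylfuran-2-yl in place of 1,2-oxazol-4-yl gives a 17-fold lower number from compound 2 to compound 3 (1.23 log units; beyond the scatter), a large step where the earlier one was modest. Set against the other methylated ring, 5-methylfuran-2-yl in place of 2-methyl-1,3-oxazol-4-yl gives a 120-fold lower number from compound 1 to compound 3 (2.08 log units; beyond the scatter), so a methyl group on the ring does not by itself fix the number: compound 1 and compound 3 both carry one, yet they stand at opposite ends of the series. Nothing at hand accounts for these steps.

In compound 3 the methyl group and the change of ring enter together, and the compounds shown do not separate them. Also open, as far as these compounds go, is how an unsubstituted furan-2-yl, a thiophene ring or a phenyl ring would read at this place.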